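Bromo for methyl on the anilino ring of compound 1

The source may hold more compounds than are shown below. What is called first, only, known or untested is meant among the compounds shown, and "the series" means these compounds.

Measured compounds:
compound 1 `Cc1ccc(Nc2cc(-c3ccccc3)oc(=O)c2)cc1` gives 0.073 uM in a functional assay on DU-145 cells (Homo sapiens) for cytotoxicity, read by MTT assay, with a stated time of 72 h; a higher number here means that more compound is needed for the effect, a lower number that less compound is needed
compound 2 `COc1ccccc1Nc1cc(-c2ccccc2)oc(=O)c1` gives 0.37 uM
compound 3 `COc1ccc(Nc2cc(C(C)C)oc(=O)c2)cc1` gives > 30 uM

Compound 1 has the lowest of the two numbers shown, with compound 2 the nearest at a higher number, a gap beyond the scatter. For compound 3 the value is a limit of this assay, not a number; the limit of the limit of > 30 uM in this assay, at which 1 of the 3 values shown sits, applies to it alone.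

Compound 4 `O=c1cc(Nc2ccc(Br)cc2)cc(-c2ccccc2)o1` differs from compound 1 in one place: bromo in place of methyl on an aromatic carbon. Going by the values given here, no measured pair shows this change, so its effect cannot be read from the data; the two groups match in heavy-atom count, ring count, donors, acceptors and charge, and a step of no more than the usual scatter, in either direction, is expected. Compound 4 is therefore estimated at 0.1 uM, within the range 0.03 uM to 0.4 uM, an expected step of a 1.4-fold higher number from compound 1 to compound 4 (0.14 log units; within the scatter).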

Compound 4, concentration for half-maximal effect: 0.34 uM
For compound 4 the middle estimate is 3.4-fold (0.53 log units) below the measured one, within the range that was stated.
By their numbers in this assay, from the lowest: compound 1; then compounds 4 and 2 (each within the scatter of the next). At a limit, above all of these: compound 3.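

In this assay, bromo in place of methyl on the 4-methylphenyl ring gives a 4.7-fold higher number from compound 1 to compound 4 (0.67 log units; beyond the scatter), so this place, para to a large group, responds to the exchange. The step is modest, yet it lies beyond the scatter, even though the two groups match in heavy-atom count, donors, acceptors and charge, so those shared counts do not fix the result at this position. Going by these compounds alone, nothing measured here accounts for the step, and the one limit among the values concerns a different compound.

The compounds shown do not tell whether other groups at this place, such as chloro, an amine or a carboxylic acid, would stay close to methyl or fall further away. They also leave open whether the same exchange would give a similar step on a core carrying a group other than phenyl.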